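The source may hold more compounds than are shown below. What is called first, only, known or untested is meant among the compounds shown, and "the series" means these compounds.

Measured so far in a functional assay on the whole organism (strain Wistar) for inhibition, with Rattus norvegicus as the target, read by paw edema, with stated times of 30 min and 3 h, at a dose of 20 mg/kg by the oral route; a higher number here means more inhibition at the dose given (going by the name of the read-out), a lower number less inhibition:
Compound 1 `Cc1cc(O)c(C2=NN(c3ccc(S(N)(=O)=O)cc3)C(c3ccccc3)C2)cc1Cl` gives 47.4%.
Compound 2 `Cc1cc(O)c(C2=NN(c3ccc(S(N)(=O)=O)cc3)C(c3ccc(Cl)cc3)C2)cc1Cl` gives 65.8%.
Compound 3 `COc1cc(C)c(Cl)cc1C1=NN(c2ccc(S(N)(=O)=O)cc2)C(c2ccccc2)C1` gives 55.3%.

Compound 3 stands second highest of the three numbers. Its gap to compound 1 is within the scatter, while compound 2 lies beyond the scatter above it. The step of a number 7.9 percentage points higher from compound 1 to compound 3 (within the scatter) shows methyl in place of hydrogen on an oxygen on an aromatic ring changing little; the step of a number 18.4 percentage points higher from compound 1 to compound 2 (beyond the scatter) shows chloro in place of hydrogen on an aromatic carbon raising inhibition beyond the scatter.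

Compound 4 `COc1cc(C)c(Cl)cc1C1=NN(c2ccc(S(N)(=O)=O)cc2)C(c2cccc(O)c2)C1` differs from compound 3 by hydroxy in place of hydrogen on an aromatic carbon. Within the data shown here, the only measured step on that same six-membered ring of carbon only is the chloro one, a number 18.4 percentage points higher from compound 1 to compound 2 (beyond the scatter); no measured step speaks of hydroxy there, and hydroxy is not chloro. In this assay the expected step is therefore small, and the estimated step of a number 2.7 percentage points higher from compound 3 to compound 4 (within the scatter) is taken as not clearly beyond the scatter. Compound 4 is expected to give 58%, with a range from 44% to 72%.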

Compound 4, a percentage reported as inhibition, in the whole organism at one dose (the size of the read-out at that dose, not a potency): 39.5%
Compound 4: middle estimate off by 18.5 percentage points, on the high side; measured number below the stated range.
By their numbers in this assay, from the lowest: compounds 4, 1 and 3 (each within the scatter of the next, the first and the last beyond it); then compound 2.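

In this assay, a number 15.8 percentage points lower from compound 3 to compound 4 (beyond the scatter) when 3-hydroxyphenyl replaces phenyl, so a substituent on this ring can lower inhibition as well as raise it. Among these compounds, the only earlier step on this ring, a number 18.4 percentage points higher from compound 1 to compound 2 (beyond the scatter), went the other way with chloro, but the two steps differ in both the entering group and the starting compound, so they show no single trend for the ring. Nothing measured here accounts for the drop with hydroxy.

Going by these compounds, whether the drop belongs to hydroxy itself or to any group on this carbon remains open, and a methoxy or an amine at the same place would help separate the two. Also open, on these data alone, is how chloro on this ring behaves starting from compound 3, and how hydroxy behaves elsewhere on the ring.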